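A few compounds are considered here, and "the series" means these few. Any claim that something is new, unique, unknown or untested is made for them only; others in the source may bear on it.

Working notes on the series. Compound 1 `Cc1cc(C)cc(-c2cnc(-c3cccnc3)c(C(=O)NCc3ccc(C(F)(F)F)c(F)c3)c2)c1` gives 4.1 nM in an assay on isolated protein for displacement of a labelled ligand from Orexin receptor type 2 (Homo sapiens), read by scintillation counting, with a stated time of 60 min; a lower number here means a stronger inhibitor, a higher number a weaker inhibitor. For the measured compounds named here, compound 2 `COc1ccc(CNC(=O)c2cc(-c3cc(C)cc(C)c3)cnc2-c2cccnc2)cc1OC` gives 0.7 nM in this assay; the change a 5.9-fold lower number from compound 1 to compound 2 (0.77 log units; beyond the scatter) is the only step measured so far, and it concerns the group on the saturated chain carbon bound to the amide-type nitrogen. On the numbers available, compound 2 stands lowest of the two, with compound 1 as its nearest neighbour.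

Compound 3 `COc1ccc(CNC(=O)c2cc(-c3cccc(Cl)c3)cnc2-c2cccnc2)cc1OC` has not yet been run in this assay. It differs from compound 2 by 3-chlorophenyl in place of 3,5-dimethylphenyl on an aromatic carbon. Going by the values given here, no measured step touches this position: the one known step alters the other end of the shared core, so nothing in the data sets the size or direction of this change. The working expectation is therefore a step of a 2.1-fold higher number from compound 2 to compound 3 (0.33 log units; beyond the scatter) no larger than the scatter or a modest loss, and compound 3 is estimated at 1.5 nM, with a range from 0.4 nM to 6 nM.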

Compound 3, inhibition constant: 1.3 nM
Estimate against measurement, compound 3: 1.2-fold (0.06 log units) above; low and high end bracket the measured number.
By their numbers in this assay, from the lowest: compounds 2 and 3 (each within the scatter of the next); then compound 1.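

For the compounds shown here, this is the first measured step at the aromatic carbon para to a pyridin-3-yl group. In this assay, 3-chlorophenyl in place of 3,5-dimethylphenyl gives a 1.9-fold higher number from compound 2 to compound 3 (0.27 log units; within the scatter), so the position accepts a single chlorine on the ring in place of two methyl groups with no difference that can be read, at least with the 3,4-dimethoxyphenyl group held constant. No supporting measurement is available to explain this equivalence.

Going by these compounds, both groups seen here are six-membered aromatic rings of carbon only, with no hydrogen-bond donors or acceptors, so the response to a ring carrying an amine or a carboxylic acid, or to a saturated cyclohexyl ring, remains open. Also open, on these data alone, is whether the two groups stay equivalent alongside the 3-fluoro-4-(trifluoromethyl)phenyl group of compound 1.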